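Swapping the aryl group of compound 1

A few compounds are considered here, and "the series" means these few. Any claim that something is new, unique, unknown or untested is made for them only; others in the source may bear on it.

Of the compounds shown here, three carry numbers so far in a functional assay on DU-145 cells (Homo sapiens) for cytotoxicity, read by trypan blue exclusion, with a stated time of 96 h (on this read-out higher numbers stand for weaker inhibition and lower numbers for stronger inhibition), and no two of them differ in one place only. Compound 1 (`COc1cc(OC)c(/C=C/S(=O)(=O)Cc2ccc(F)c(N)c2)c(OC)c1`) at 2500 nM and compound 2 (`COc1ccc(CS(=O)(=O)/C=C/c2cc(F)c(F)cc2F)cc1N`) at 5000 nM lie within the scatter of each other, together at the low end of the three numbers. Compound 3 (`COc1ccc(CS(=O)(=O)/C=C/c2c(OC)cccc2OC)cc1[N+](=O)[O-]`) at 20000 nM has a higher number than compound 1, and that gap is beyond the scatter.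

Compound 4 (`COc1ccc(CS(=O)(=O)/C=C/c2c(OC)cc(OC)cc2OC)c(N)c1`) is still to be measured. It carries 2-amino-4-methoxyphenyl in place of 3-amino-4-fluorophenyl on a saturated chain carbon bound to a sulfonyl sulfur and otherwise keeps the core of compound 1. Within the data shown here, no measured step isolates this change, so its size in this assay cannot be read from the data. Compound 1 and compound 2 differ in more than one place and still stay within the scatter of each other, which gives only thin support for a small effect. The estimated step of a 1.7-fold lower number from compound 1 to compound 4 (0.22 log units; within the scatter) is expected to stay within the scatter, with a slight lean towards a lower number. Compound 4 is expected at about 1500 nM (estimated range 250 nM to 8000 nM).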

Compound 4, half-maximal inhibitory concentration: 25 nM
Compound 4: middle estimate off by 60-fold (1.78 log units), on the high side, outside the stated range (below it).
By their numbers in this assay, from the lowest: compound 4; then compounds 1 and 2 (each within the scatter of the next); then compound 3.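

In this assay, among these compounds, placing 2-amino-4-methoxyphenyl in place of 3-amino-4-fluorophenyl on a saturated chain carbon bound to a sulfonyl sulfur gives a 100-fold lower number from compound 1 to compound 4 (2.00 log units; beyond the scatter), the first change that can be read at a single place. Among the compounds shown here, the read-out is therefore highly sensitive to the aryl group at this position, which the earlier compounds could not show, as none of them differed in one place only. No measurement on hand bears on the mechanism behind a step of this size, and it stays an observation without an explanation.

The change replaces the whole aryl group, so the compounds shown do not separate the contribution of the methoxy group entering, the fluorine leaving and the different placement of the amino group on the ring. Also open, going by these compounds, is whether the low number of compound 4 survives when a hydroxyl group, a carboxylic acid or a dimethylamino group takes the place of the amino group, or when a longer chain separates the aryl group from the sulfonyl sulfur.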